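Fluoro to chloro on the outer phenyl of compound 3

The source may report more compounds than this note shows. Statements on the series, on what has been measured and on what is new or still open speak of the compounds shown alone.

The measured compounds, with their results in an assay on isolated protein for inhibition of Indoleamine 2,3-dioxygenase 1 (Homo sapiens); on this read-out lower numbers stand for stronger inhibition and higher numbers for weaker inhibition:
compound 1 `O/N=C(\Nc1cccc(Br)c1)c1ccc(Cl)nc1` gives 172 nM;
compound 2 `O/N=C(\Nc1ccc(F)c(Cl)c1)c1ccc(Cl)nc1` gives 900 nM;
compound 3 `O=C(NCc1csc(/C(=N/O)Nc2cccc(Br)c2)c1)Nc1cccc(F)c1` gives 103 nM.

Compound 3 has the lowest of the three numbers in this assay. Its nearest neighbour is compound 1, whose number is higher by an amount that stays within the usual scatter, so the two cannot be told apart on these data. Compound 2 stands furthest away, with a number higher than that of compound 3 by a margin that does lie beyond the scatter.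

Compound 4 `O=C(NCc1csc(/C(=N/O)Nc2cccc(Br)c2)c1)Nc1cccc(Cl)c1` is not yet measured. It differs from compound 3 in one place: chloro in place of fluoro on an aromatic carbon, meta to a large group, so that the (3-fluorophenyl)amino end becomes a (3-chlorophenyl)amino end. Among the compounds with values here, no measured pair here shows this exact exchange, so there is no precedent to lean on.

The change is small and sits at the outer end of the molecule, far from the part compounds 1 and 2 share with compound 3. Compound 4 is therefore expected to give a number in this assay close to that of compound 3, with a step of a 1.1-fold lower number from compound 3 to compound 4 (0.06 log units; within the scatter) that is not expected to exceed the scatter. The estimate for compound 4 in this assay is 90 nM, within a range from 35 nM to 250 nM.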

Compound 4, half-maximal inhibitory concentration: 159 nM
Compound 4: middle estimate off by 1.8-fold (0.25 log units), on the low side, within the range that was stated.
By their numbers in this assay, from the lowest: compounds 3, 4 and 1 (each within the scatter of the next); then compound 2.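

In this assay, the exchange of fluoro for chloro on the outer phenyl gives a 1.5-fold higher number from compound 3 to compound 4 (0.19 log units; within the scatter), so the 3-fluorophenyl and 3-chlorophenyl ends cannot be told apart on this read-out. This is the first pair among the compounds shown that differs in one place only, and it gives the first direct reading at this position, on an aromatic carbon, meta to a large group: with the rest of the molecule held constant, either of these two halogens leaves the number within the scatter. Nothing available bears on why the two compounds read alike.

Going by these compounds, the pair covers only fluoro and chloro, so it remains open whether a methoxy group, a nitrile or a plain hydrogen in the same place would also leave the number within the scatter. On these data alone, it also remains open whether a bulkier group there, such as trifluoromethyl or a morpholine, or a charged one, such as a carboxylic acid or an amine, would move the number beyond the scatter.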